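Moving the Chlorine on a Pyridyl Sulfonamide

The source may report more compounds than this note shows. Statements on the series, on what has been measured and on what is new or still open speak of the compounds shown alone.

Compound 1 `CC1CCN(C2CCN(S(=O)(=O)c3cccnc3Cl)CC2)CC1` carries a 2-chloropyridin-3-yl group on the sulfonyl sulfur of its core. In a functional assay on DLD-1 cells (Homo sapiens) for antiproliferative activity, read by CellTiter-Glo, with a stated time of 72 h (a lower number here means a stronger inhibitor, a higher number a weaker inhibitor), compound 1 gives > 5000 nM, which is a limit of the assay rather than a measured number. Compound 2 `COc1cc(C)ccc1S(=O)(=O)N1CCC(N2CCC(C)CC2)CC1` in this assay gives > 5000 nM, likewise a limit. Compound 3 `CC1CCN(C2CCN(S(=O)(=O)c3ccc(Br)cc3OC(F)(F)F)CC2)CC1` in this assay gives 5 nM. Compound 1 therefore stands at the limit of > 5000 nM in this assay, at which 2 of the 3 values shown sit, and nothing measured places it more precisely than that.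

Compound 4 `CC1CCN(C2CCN(S(=O)(=O)c3ccc(Cl)nc3)CC2)CC1` differs from compound 1 in a single place: 6-chloropyridin-3-yl in place of 2-chloropyridin-3-yl on a sulfonyl sulfur. The two share every atom and differ only in where the chlorine and the ring nitrogen sit relative to the sulfonyl sulfur.

For the measured compounds named here, no step between two measured compounds is available here, so the size of this change in this assay can only be guessed. Going by the values given here, compound 3 shows that the shared core can carry strong activity, but its aryl group differs from that of compound 1 in more than one place and gives no single step to lean on. The shift from compound 1 to compound 4 is expected to stay small, likely within the scatter, as an at least 1.2-fold lower number from compound 1 to compound 4 (0.09 log units; that floor lies within the scatter). Compound 4 is estimated at 4000 nM, with a range from 800 nM to 20000 nM.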

Compound 4, half-maximal inhibitory concentration: 3700 nM
Estimate against measurement, compound 4: 1.1-fold (0.03 log units) above; measured number inside the range.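

In this assay compound 4 gives 3700 nM, a number that can actually be read on this scaffold with a chloropyridinyl group. Compound 1, by contrast, gives only a limit. Placing 6-chloropyridin-3-yl in place of 2-chloropyridin-3-yl on the sulfonyl sulfur gives an at least 1.3-fold lower number from compound 1 to compound 4 (0.13 log units; that floor lies within the scatter), but this is a floor and not a size, and the true step could be that small or much larger, since one end of it is not a number: the limit of > 5000 nM in this assay, at which 2 of the 4 values shown sit.

For the compounds shown here, no one-place step links compound 3 to either chloropyridinyl compound, so how much of its activity traces to its bromine or its trifluoromethoxy group remains unresolved. Going by these compounds, it also remains open whether an amine or a nitrile in place of the chlorine on the pyridin-3-yl group would move the number in this assay, and whether a bromine there would behave as the chlorine of compound 4 does.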